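The source may report more compounds than this note shows. Statements on the series, on what has been measured and on what is new or still open speak of the compounds shown alone.

Measured in a functional assay on MCF7 cells (Homo sapiens) for cytotoxicity, read by MTT assay, with a stated time of 24 h; on this read-out higher numbers stand for weaker inhibition and lower numbers for stronger inhibition:
compound 1, `COc1ccccc1N1CCN(CC(=O)N2CCN(c3nnc(-c4ccccc4)c(-c4ccccc4)n3)CC2)CC1`, gives 167000 nM.
compound 2, `O=C(CN1CCN(c2ccccc2Cl)CC1)N1CCN(c2nnc(-c3ccccc3)c(-c3ccccc3)n2)CC1`, gives 263000 nM.
compound 3, `COc1cccc(N2CCN(CC(=O)N3CCN(c4nnc(-c5ccc(Cl)cc5)c(-c5ccc(Cl)cc5)n4)CC3)CC2)c1`, gives 149000 nM.

Compound 1 and compound 2 share a core and differ by chloro in place of methoxy on an aromatic carbon; the step is a 1.6-fold higher number from compound 1 to compound 2 (0.20 log units; within the scatter). Compound 3 carries a different core, and the difference between the core of compound 3 and that of compound 1 is not broken down here. Compound 4, `O=C(CN1CCN(c2cccc(Cl)c2)CC1)N1CCN(c2nnc(-c3ccc(Cl)cc3)c(-c3ccc(Cl)cc3)n2)CC1`, is yet to be measured in this assay. It differs from compound 3 by chloro in place of methoxy on an aromatic carbon. This is the same kind of change as that between compound 1 and compound 2, but the place differs: ortho to a large group in the earlier pair, meta to a large group here. Within the data shown here, a step of similar size is expected, a 1.5-fold higher number from compound 3 to compound 4 (0.17 log units; within the scatter), because a 1.6-fold higher number from compound 1 to compound 2 (0.20 log units; within the scatter) is the only measured step of this kind. Compound 4 is therefore estimated at 220000 nM, within 100000 nM to 450000 nM.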

Compound 4, half-maximal inhibitory concentration: > 803000 nM
Compound 4: only a limit was reported (the forecaster's own chance of this, stated with the estimate: 20%); middle value at least 3.6-fold (0.56 log units) from the limit.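

In this assay, chloro in place of methoxy gives an at least 5.3-fold higher number from compound 3 to compound 4 (0.73 log units; beyond the scatter), so the change does not carry over at one size from the core of compound 1 to the core of compound 3: the same change on two cores in this assay, a 1.6-fold higher number (0.20 log units; within the scatter) from compound 1 to compound 2 and an at least 5.3-fold higher number (0.73 log units; beyond the scatter) from compound 3 to compound 4, at least 3.4-fold (0.53 log units) apart, beyond the scatter of two such steps

Compound 4 gives > 803000 nM, which is a limit of the assay and not a number: the limit of > 803000 nM in this assay, at which 1 of the 4 values shown sits.

From the compounds shown here alone, the true size of the step on this core remains unknown, and with one pair per core, and the place on the aromatic ring differing along with the core, the gap cannot be assigned to either.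

Still open, going by these compounds, is how chloro reads at each place on a single core. Also open, on these data alone, is whether fluoro, a nitrile or an amine in place of methoxy follows compound 2 or compound 4.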